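This account rests on a few compounds, and the source may have more. Where it says the series, first, only, none or still open, it means among the compounds named here.

The series shares the core seen in compound 1, whose structure is `Cc1cccc2c1NC(=O)C2(c1ccc(O)cc1)C1CCCCCC1`. Compound 1 is known in a functional assay on PC-3 cells (Homo sapiens) for cytotoxicity, read by WST assay, with a stated time of 72 h (on this read-out lower numbers stand for stronger inhibition and higher numbers for weaker inhibition), only as a limit: in this assay compound 1 gives > 1000 nM. One measured step exists. Compound 2, with the structure `O=C1Nc2c(C(F)(F)F)cccc2C1(c1ccc(O)cc1)C1CCCCCC1`, differs from compound 1 by trifluoromethyl in place of methyl on an aromatic carbon, and in this assay compound 2 gives 91 nM. That step is an at least 10-fold lower number from compound 1 to compound 2 (1.04 log units; beyond the scatter), and since compound 1 sits at the limit of > 1000 nM in this assay, at which 1 of the 2 values shown sits, the true size of the step is not fixed.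

Compound 3, whose structure is `Cc1c(Cl)ccc2c1NC(=O)C2(c1ccc(O)cc1)C1CCCCCC1`, is built instead by chloro in place of hydrogen on an aromatic carbon. Among the compounds with values here, no measured step touches this position, and the only step available, that from compound 1 to compound 2, changes a different group at a different place. It therefore offers no firm guide to the direction or size of the change here. For compound 3 the author expects a modest improvement, a step of an at least 1.6-fold lower number from compound 1 to compound 3 (0.22 log units; that floor lies within the scatter), and estimates a value of 600 nM, within a range from 150 nM to 3000 nM.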

Compound 3, half-maximal inhibitory concentration: 150 nM
For compound 3 the middle estimate is 4.0-fold (0.60 log units) above the measured one; measured number inside the range.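

The position ortho to a methyl group, meta to a fused ring and para to a fused ring now has a measured result of its own: in this assay, chloro in place of hydrogen gives an at least 6.6-fold lower number from compound 1 to compound 3 (0.82 log units; beyond the scatter). Within the data shown here, this shows that a change at this aromatic carbon, with the methyl group of compound 1 kept in place, can lower the number beyond the scatter, so the trifluoromethyl change in compound 2 is no longer the only single change on the core of compound 1 known to do so. The step gives only a floor and not a true size because compound 1 is known only as a limit: the limit of > 1000 nM in this assay, at which 1 of the 3 values shown sits.

The compounds shown leave open whether the step is particular to chloro or would also follow from another group at this carbon, such as fluoro, a methoxy group or an amine. They also leave open what chloro and trifluoromethyl would give together on the shared core, and compound 2 and compound 3 differ in more than one place, so they offer no direct comparison of the two changes.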